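The source may hold more compounds than are shown below. What is called first, only, known or untested is meant among the compounds shown, and "the series" means these compounds.

Compound 3 `CCOc1ccc(NC(=O)/C=C/c2coc3cc(OC)ccc3c2=O)cc1` gives 460000 nM in an ADME assay on HepG2 2.2.15 cells (Homo sapiens) for cytotoxicity, read by MTT assay, with stated times of 48 h and 9 days (on this read-out higher numbers stand for lower toxicity in this test and lower numbers for higher toxicity in this test), the second highest of the three numbers; its nearest neighbour is compound 1 `COc1ccc2c(=O)c(/C=C/C(=O)NCc3cccc(F)c3)coc2c1`, which gives 475000 nM, a gap within the scatter, while compound 2 `COc1ccc(CNC(=O)/C=C/c2coc3cc(OC)ccc3c2=O)cc1`, which gives 43000 nM, sits furthest away, as the step of an 11-fold higher number from compound 2 to compound 3 (1.03 log units; beyond the scatter) shows. Compound 4 `COc1ccc2c(=O)c(/C=C/C(=O)NCc3ccc(C)cc3)coc2c1` differs from compound 3 by 4-methylbenzyl in place of 4-ethoxyphenyl on an amide-type nitrogen.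

For the measured compounds named here, two measured steps bear on this change. The step of a 1.0-fold lower number from compound 1 to compound 3 (0.01 log units; within the scatter) shows that exchanging a 3-fluorobenzyl for the 4-ethoxyphenyl left the number unmoved, whereas an 11-fold higher number from compound 2 to compound 3 (1.03 log units; beyond the scatter) shows that the same 4-ethoxyphenyl in place of a 4-methoxybenzyl raised it strongly. Going by the values given here, a benzyl group on the amide nitrogen therefore has given both an unchanged and a much lower number, depending on what it carries; the 4-methylbenzyl has no precedent here. The expected step of a 3.1-fold lower number from compound 3 to compound 4 (0.49 log units; beyond the scatter) for compound 4 is toward a lower number, of uncertain size. Compound 4 is estimated at 150000 nM, between 30000 nM and 500000 nM.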

Compound 4, half-maximal cytotoxic concentration: 257000 nM
The estimate for compound 4 lay 1.7-fold (0.23 log units) below the measured number; measured number inside the range.
By their numbers in this assay, from the lowest: compound 2; then compounds 4, 3 and 1 (each within the scatter of the next).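

In this assay, 4-methylbenzyl on the amide-type nitrogen stands level with 4-ethoxyphenyl, at a 1.8-fold lower number from compound 3 to compound 4 (0.25 log units; within the scatter), and the swap of 3-fluorophenyl for 4-methylphenyl on the saturated chain carbon also stays within the scatter, at a 1.8-fold lower number from compound 1 to compound 4 (0.27 log units; within the scatter). For the compounds shown here, compound 2 is now the one compound of the four set apart from all the others, and methyl in place of methoxy on an aromatic carbon alone gives a 6.0-fold higher number from compound 2 to compound 4 (0.78 log units; beyond the scatter), so the benzyl amides do not go low as a class. No measured finding accounts for this difference.

On these data alone, it remains open whether an ethoxy, hydroxyl or dimethylamino group in place of that methoxy would give a number near that of compound 2 or near those of the other three. Also open, as far as these compounds go, is how a 4-methoxyphenyl directly on the amide-type nitrogen would compare.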